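Phenyl for furan-2-yl on the shared core

A few compounds are considered here, and "the series" means these few. Any claim that something is new, unique, unknown or untested is made for them only; others in the source may bear on it.

Compound 1 `O=C(O)/C=C/c1ccc(NC(=O)C2(NC(=O)c3ccc4c(c3)nc(-c3ccco3)n4C3CCCCC3)CCC2)cc1` is tested in an ADME assay on Huh-7 cells (Homo sapiens) for cytotoxicity; on this read-out lower numbers stand for higher toxicity in this test and higher numbers for lower toxicity in this test. In this assay compound 1 gives > 10 uM, which is a limit of the assay and not a number. Compound 2 `O=C(O)/C=C/c1ccc(NC(=O)C2(NC(=O)c3ccc4c(c3)nc(-c3ccccn3)n4C3CCCCC3)CCCC2)cc1` carries a different ring at the amide and a different aromatic group on the core. In this assay compound 2 gives > 10 uM, again a limit of the assay rather than a number. Compound 1 therefore stands at the limit of > 10 uM in this assay, at which 2 of the 2 values shown sit. Going by the values given here, no measured step between the two compounds exists, and the two limits allow no ordering of compound 1 against compound 2.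

Compound 3 `O=C(O)/C=C/c1ccc(NC(=O)C2(NC(=O)c3ccc4c(c3)nc(-c3ccccc3)n4C3CCCCC3)CCC2)cc1` remains to be measured in this assay. It differs from compound 1 by phenyl in place of furan-2-yl on an aromatic carbon. The step that the limit leaves unreadable from compound 1 to compound 3 is expected to be none beyond the scatter, with the read-out most likely reported again as a limit. Compound 3 is estimated at 15 uM in this assay, within a range from 5 uM to 50 uM.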

Compound 3, half-maximal toxic concentration: > 10 uM
Compound 3: no number, only a limit; the forecaster's own chance of this, stated with the estimate: 75%; the middle value is on the limit's open side.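

In this assay compound 3 gives > 10 uM, which is a limit of the assay and not a number. No step from compound 1 to compound 3 can be read: the limit of > 10 uM in this assay, at which 3 of the 3 values shown sit.

The compounds shown leave open whether phenyl and furan-2-yl differ at all on this read-out.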